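A few compounds are considered here, and "the series" means these few. Any claim that something is new, unique, unknown or untested is made for them only; others in the source may bear on it.

Of the compounds shown here, three built on one shared core have been tested in an assay on MDA-MB-231 cells for binding affinity to C-X-C chemokine receptor type 4 (Homo sapiens), read by microscopy, with stated times of 10 min and 30 min; on this read-out higher numbers stand for an effect only at larger amounts of compound and lower numbers for an effect already at smaller amounts. Compound 1 `Cc1cccc(S(=O)(=O)NCc2ccc(CNC(=O)c3ccc(CNc4ncccn4)cc3)cc2)c1` gives 100 nM. Compound 2 `O=C(NCc1ccc(CNS(=O)(=O)c2cccc3ccccc23)cc1)c1ccc(CNc2ncccn2)cc1` gives 1000 nM, and compound 3 `O=C(NCc1ccc(CNS(=O)(=O)c2ccc(-c3ccc(F)cc3)cc2)cc1)c1ccc(CNc2ncccn2)cc1` gives 1000 nM; compound 2 thus stands level with compound 3, the two together carrying the highest numbers of the three. Among the compounds with values here, the only measured single-point step, a 10-fold higher number from compound 1 to compound 2 (1.00 log units; beyond the scatter), shows how much the number moved when the group on the sulfonyl sulfur was exchanged. Compound 4 `O=C(NCc1ccc(CNS(=O)(=O)c2cccc(F)c2)cc1)c1ccc(CNc2ncccn2)cc1` is the next variation: 3-fluorophenyl in place of naphthalen-1-yl on a sulfonyl sulfur. Because a 10-fold higher number from compound 1 to compound 2 (1.00 log units; beyond the scatter) shows the number rising when a single ring on the sulfonyl sulfur was exchanged for the two-ring group, and the present change returns to a single ring on the sulfonyl sulfur, compound 4 is expected to show a 5.0-fold lower number from compound 2 to compound 4 (0.70 log units; beyond the scatter). Compound 4 is therefore estimated at 200 nM, in the range 60 nM to 700 nM.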

Compound 4, effective concentration (reported as EC, without a stated level of effect): 1000 nM
Beside the measured number, compound 4's estimate is 5.0-fold (0.70 log units) below it, outside the stated range (above it).
By their numbers in this assay, from the lowest: compound 1; then compounds 2, 3 and 4 (each within the scatter of the next).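

Exchanging naphthalen-1-yl for 3-fluorophenyl on the sulfonyl sulfur leaves the number where it was (no change at the digits printed from compound 2 to compound 4 (within the scatter)), so a single ring at this position does not by itself bring the number down. Fluoro in place of methyl on an aromatic carbon gives a clear rise (a 10-fold higher number from compound 1 to compound 4 (1.00 log units; beyond the scatter)), so the lower number of compound 1 goes with its methyl and not simply with having one ring. No evidence is at hand to explain this. Still open, going by these compounds, is how a chloro, methoxy or amino group in place of that methyl would compare with compound 1.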